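Removing chloro from the methyl-bearing biaryl series

The compounds below may be only part of what the source reports. "The series", "measured", "known", "first", "only" and "open" are said of these compounds alone.

Measured in a functional assay on A2780 cells (Homo sapiens) for inhibition, read by sulforhodamine B assay; on this read-out lower numbers stand for stronger inhibition of growth and higher numbers for weaker inhibition of growth:
- compound 1 `Cc1ccc2[nH]c(-c3ccc(-c4ccc(-c5cccc(Cl)c5)cc4)cc3)nc2c1`: 2800 nM
- compound 2 `Clc1cccc(-c2ccc(-c3ccc(-c4nc5ccccc5[nH]4)cc3)cc2)c1`: 31100 nM

Of these two, compound 1 holds the lower number, so it shows the stronger growth inhibition. The next compound, compound 3 `Cc1ccc2[nH]c(-c3ccc(-c4ccc(-c5ccccc5)cc4)cc3)nc2c1`, is not yet measured. It differs from compound 1 by hydrogen in place of chloro on an aromatic carbon, which is hydrogen in place of chloro on an aromatic carbon. Among the measured compounds shown here, no measured step covers this change. For the measured compounds named here, the only step, an 11-fold higher number from compound 1 to compound 2 (1.05 log units; beyond the scatter), removes methyl and not chloro, so it bears on the change only indirectly. It does show that losing one small substituent can move this assay well beyond the scatter. A higher number is therefore expected, though a smaller move than that step, and with wide uncertainty. The expected step is a 2.1-fold higher number from compound 1 to compound 3 (0.33 log units; beyond the scatter). For compound 3 the estimated value is 6000 nM, with an expected range of 1800 nM to 20000 nM.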

Compound 3, concentration for 50% growth inhibition: 41200 nM
For compound 3 the middle estimate is 6.9-fold (0.84 log units) below the measured one; the measured number lies above the stated range.
By their numbers in this assay, from the lowest: compound 1; then compounds 2 and 3 (each within the scatter of the next).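

In this assay, the change from 3-chlorophenyl to phenyl costs a single heavy atom, yet it gives a large step (a 15-fold higher number from compound 1 to compound 3 (1.17 log units; beyond the scatter)). Chloro therefore matters at this position, which the methyl step (an 11-fold higher number from compound 1 to compound 2 (1.05 log units; beyond the scatter)) could not show, and removing either substituent from compound 1 moves the number beyond the scatter. No supporting data explain the size of the chloro step.

Whether this effect is specific to chloro remains open, since no other group at this place, such as methoxy, an amine or a carboxylic acid, appears among these compounds. Among the compounds shown here, with no compound here lacking both chloro and methyl, it also remains open whether the two effects add together or overlap.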